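This account rests on a few compounds, and the source may have more. Where it says the series, first, only, none or still open, it means among the compounds named here.

Measured compounds in a functional assay (brain) for displacement of a labelled ligand, with Rattus norvegicus as the target; on this read-out higher numbers stand for weaker inhibition and lower numbers for stronger inhibition:
- compound 1 `CC[C@]1(c2ccc(O)cc2)OC[C@H]([C@@H]2CCCCN2)O1`: compound 1 gives 19900 nM
- compound 2 `CN1CCCC[C@H]1[C@H]1COC(c2ccccc2)(c2ccccc2)O1`: compound 2 gives 4400 nM
- compound 3 `CCN1CCCC[C@H]1[C@H]1COC(c2ccccc2)(c2ccccc2)O1`: compound 3 gives 6900 nM

Compound 3 stands second highest of the three numbers in this assay. Its nearest neighbour is compound 2, and the step of a 1.6-fold higher number from compound 2 to compound 3 (0.20 log units; within the scatter) lies within the scatter, so the two cannot be ordered. Going by the values given here, compound 1 stands furthest from it, with a number higher than compound 3 by more than the scatter; no single-point step connects these two, so only the two values themselves can be compared.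

Compound 4 `CCCN1CCCC[C@H]1[C@H]1COC(c2ccccc2)(c2ccccc2)O1` is not yet measured. It differs from compound 3 by methyl in place of hydrogen on a saturated chain carbon, two bonds along the chain from an amine nitrogen in a ring. Among the compounds with values here, the only measured step that bears on it is the one from compound 2 to compound 3, a 1.6-fold higher number from compound 2 to compound 3 (0.20 log units; within the scatter), which is the same difference cut one bond closer to the ring nitrogen and stayed within the scatter. On that basis no step beyond the scatter is expected in this assay from compound 3 to compound 4; if anything a slightly higher number, estimated as a 1.2-fold higher number from compound 3 to compound 4 (0.09 log units; within the scatter).

For compound 4 the expected value in this assay is 8500 nM, with a range from 4000 nM to 18000 nM.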

Compound 4, inhibition constant: 6800 nM
Estimate against measurement, compound 4: 1.3-fold (0.10 log units) above; the measured number falls inside the stated range.
By their numbers in this assay, from the lowest: compounds 2, 4 and 3 (each within the scatter of the next); then compound 1.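

In this assay, the change from ethyl to propyl on the amine nitrogen in the ring gives a 1.0-fold lower number from compound 3 to compound 4 (0.01 log units; within the scatter), so a second extension of this chain, one bond further out, also stays within the scatter. The two extensions taken together, methyl to propyl, give a 1.5-fold higher number from compound 2 to compound 4 (0.19 log units; within the scatter), which is also within the scatter, so compounds 2, 3 and 4 cannot be ordered and this position shows no measurable dependence on chain length across methyl, ethyl and propyl. No supporting data bear on this result.

The compounds shown leave open whether a longer chain such as butyl, or a benzyl or hydroxyethyl group, on this nitrogen would remain within the scatter of these three compounds or would finally separate from them. Also open, from the compounds shown here alone, is how the core of compound 2 reads with hydrogen in place of the methyl on that nitrogen, since every compound sharing this core here carries a saturated chain at that position.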